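The source may report more compounds than this note shows. Statements on the series, on what has been measured and on what is new or still open speak of the compounds shown alone.

Measured so far in a functional assay on MCF7 cells (Homo sapiens) for antiproliferative activity, read by MTT assay, with a stated time of 24 h (a lower number here means a stronger inhibitor, a higher number a weaker inhibitor), for this series:
Compound 1 `COC(=O)c1scc(-c2ccc(NC(=O)c3ccc4ccccc4c3)cc2)c1OC` gives 90 nM
Compound 2 `COC(=O)c1scc(-c2ccc(NC(=O)c3ccc(F)c(Cl)n3)cc2)c1OC` gives 10300 nM
Compound 3 `COC(=O)c1scc(-c2ccc(NC(=O)c3ccc(C#N)nc3)cc2)c1OC` gives 9540 nM

Compound 3 stands at the high end of these numbers, level with compound 2 (a 1.1-fold lower number from compound 2 to compound 3 (0.03 log units; within the scatter)) and far from the naphthalen-2-yl amide (a 110-fold higher number from compound 1 to compound 3 (2.03 log units; beyond the scatter)). Next is compound 4 `COC(=O)c1scc(-c2ccc(NC(=O)c3ccc(C(F)(F)F)cc3)cc2)c1OC`, not yet measured. It carries 4-(trifluoromethyl)phenyl in place of 6-cyanopyridin-3-yl on a carbonyl carbon.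

The bearing steps are the two that leave the naphthalen-2-yl group, both large (a 110-fold higher number from compound 1 to compound 2 (2.06 log units; beyond the scatter); a 110-fold higher number from compound 1 to compound 3 (2.03 log units; beyond the scatter)). The exchange of one pyridinyl group for the other stayed within the scatter (a 1.1-fold lower number from compound 2 to compound 3 (0.03 log units; within the scatter)). Among the measured compounds, only compound 1 (90 nM) has an acyl ring of carbon only, and compound 4 shares that feature. For the measured compounds named here, no measured compound carries a phenyl group, however, and three compounds establish no rule. In this assay a lower number is therefore expected, of moderate size and short of the full distance to the naphthalen-2-yl amide. The estimated step is a drop (a 5.3-fold lower number from compound 3 to compound 4 (0.72 log units; beyond the scatter)). For compound 4 the estimated value is 1800 nM (expected range 250 nM to 9000 nM).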

Compound 4, half-maximal inhibitory concentration: 24600 nM
Estimate against measurement, compound 4: 14-fold (1.14 log units) below, and the stated range ends below it.
By their numbers in this assay, from the lowest: compound 1; then compounds 3 and 2 (each within the scatter of the next); then compound 4.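

In this assay, a carbon-only acyl ring does not by itself give a low number at this position: the 4-(trifluoromethyl)phenyl amide stands above both pyridinyl amides (a 2.6-fold higher number from compound 3 to compound 4 (0.41 log units; beyond the scatter)) (a 2.4-fold higher number from compound 2 to compound 4 (0.38 log units; beyond the scatter)). The gap to the naphthalen-2-yl amide is the widest in the series so far (a 270-fold higher number from compound 1 to compound 4 (2.44 log units; beyond the scatter)), so among these four compounds, only compound 1 has a low number, while the three groups with one six-membered aromatic ring on the carbonyl carbon all lie far above it. No measurement shown accounts for this order.

The step from compound 3 to compound 4 changes the ring atoms and the substituent together, so the compounds shown cannot separate the part played by the ring nitrogen from that of the nitrile or trifluoromethyl group. An unsubstituted phenyl, a 4-methoxyphenyl or a quinolin-3-yl group on the same carbonyl carbon would test whether the low number stays with the naphthalen-2-yl group alone or extends to other acyl rings.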